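The source may hold more compounds than are shown below. What is called first, only, known or untested is meant among the compounds shown, and "the series" means these compounds.

In an assay on isolated protein for binding affinity to corticotropin-releasing factor receptor 1 (Homo sapiens) (a lower number here means a stronger inhibitor, a higher number a weaker inhibitor), compound 1 `C=CCN(c1nc(C)nc(N(CC)c2ccc(C(C)C)cc2Br)n1)C1CC1` gives 5 nM. Compound 3 `CCN(CC)c1cc(C)nc(N(CC)c2ccc(C(C)=O)cc2Br)n1` gives 5 nM, and compound 2 `CCN(CC)c1nc(C)nc(N(CC)c2ccc(N(C)C)cc2Br)n1` gives 6 nM. Compound 1 thus stands level with compound 3 at the digits shown, and the gap to compound 2 lies within the scatter, so the three numbers cannot be told apart. Among the compounds with values here, none of the three compounds differs from another in only one place, so no single step among measured compounds can be read out.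

Compound 4 `CCCN(CCC)c1nc(C)nc(N(CC)c2ccc(C(C)C)cc2Br)n1` differs from compound 1 in one place: dipropylamino in place of allyl(cyclopropyl)amino on an aromatic carbon. The two amino groups carry the same count of heavy atoms, and the measured compounds 2 and 3, which carry yet another amino group on the core, sit within the scatter of compound 1. On this basis the step of a 1.2-fold higher number from compound 1 to compound 4 (0.08 log units; within the scatter) is expected to stay within the scatter, with no change of direction worth naming. Compound 4 is therefore estimated at 6 nM, with a range from 2 nM to 20 nM.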

Compound 4, inhibition constant: 4 nM
Compound 4: middle estimate off by 1.5-fold (0.18 log units), on the high side; the measured number falls inside the stated range.
By their numbers in this assay, from the lowest: compounds 4, 1, 3 and 2 (each within the scatter of the next).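

In this assay, within the data shown here, the exchange of allyl(cyclopropyl)amino for dipropylamino gives the first single-place comparison in this set, a 1.3-fold lower number from compound 1 to compound 4 (0.10 log units; within the scatter), so this position, on an aromatic carbon between two ring nitrogen atoms, accepts the change without a difference that can be told from the scatter. Dipropylamino has no ring and no double bond outside aromatic rings, so in this pair neither feature of allyl(cyclopropyl)amino is needed to keep the number at this level. Nothing measured here gives a reason for this result.

The compounds shown leave open how far this position can be varied at other chain sizes, such as with dimethylamino or dibutylamino. They also leave open whether a chain carrying a hydroxyl group or an ether oxygen would hold the same level.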